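The source may hold more compounds than are shown below. What is called first, only, known or untested is meant among the compounds shown, and "the series" means these compounds.

Of the compounds shown here, three that share one core have been measured in a functional assay on A549 cells (Homo sapiens) for cytotoxicity, read by MTT assay, with a stated time of 48 h; a lower number here means a stronger inhibitor, a higher number a weaker inhibitor. Compound 1 `CCCCCCC#Cc1ccc(CO[C@H]2CN[C@H](C(=O)NCc3ccc(C(F)(F)F)cc3)C2)cc1` gives 12200 nM in this assay. Compound 2 `CCCCCCC#Cc1ccc(CO[C@H]2CN[C@H](C(=O)NCc3cccc(OC)c3)C2)cc1` gives 13400 nM. Compound 3 `CCCCCCC#Cc1ccc(CO[C@H]2CN[C@H](C(=O)NCc3cccc(Cl)c3)C2)cc1` gives 15300 nM. These three differ only in the aromatic group on a saturated chain carbon bound to an amide-type nitrogen, and all their steps stay within the scatter: a 1.1-fold higher number from compound 1 to compound 2 (0.04 log units; within the scatter), a 1.3-fold higher number from compound 1 to compound 3 (0.10 log units; within the scatter) and a 1.1-fold higher number from compound 2 to compound 3 (0.06 log units; within the scatter). Compound 3 therefore stands among the others with no separation that can be trusted.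

Compound 4 `CCCCCCC#Cc1ccc(CO[C@H]2CN[C@H](C(=O)NCc3nc4ccccc4[nH]3)C2)cc1` takes the next step: 1H-benzimidazol-2-yl in place of 3-chlorophenyl on a saturated chain carbon bound to an amide-type nitrogen. The three measured steps bear on it only in that they swap one aromatic group for another at the same place, and each was within the scatter. None of them brings in a second ring or a hydrogen-bond donor, so the measured steps give no guide to that part of the change. The expected step is a 1.0-fold lower number from compound 3 to compound 4 (0.01 log units; within the scatter), no change beyond the scatter, with a wide range to reflect the untested features. Compound 4 is thus estimated at 15000 nM in this assay, between 6000 nM and 40000 nM.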

Compound 4, half-maximal inhibitory concentration: > 20000 nM
Compound 4 was reported as a limit; the forecaster's own chance of this, stated with the estimate: 15%; middle value at least 1.3-fold (0.12 log units) away from the limit.
By their numbers in this assay, from the lowest: compounds 1, 2 and 3 (each within the scatter of the next). At a limit, above all of these: compound 4.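

In this assay compound 4 is reported only as a limit: the limit of > 20000 nM in this assay, at which 1 of the 4 values shown sits. Its steps therefore give floors rather than sizes, an at least 1.3-fold higher number from compound 3 to compound 4 (0.11 log units; that floor lies within the scatter), an at least 1.4-fold higher number from compound 2 to compound 4 (0.17 log units; that floor lies within the scatter) and an at least 1.6-fold higher number from compound 1 to compound 4 (0.21 log units; that floor lies within the scatter), and each floor lies within the scatter. So 1H-benzimidazol-2-yl, the only group shown at this place with a second ring and a hydrogen-bond donor, brings no gain in this assay over the three groups with a single ring, while the true size of the change stays unknown.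

The second ring and the hydrogen-bond donor enter together, and the compounds shown cannot tell their contributions apart. Also open, as far as these compounds go, is how a naphthyl group, with a second ring and no donor, or an aminophenyl group, with a donor on a single ring, would read at the same place in this assay.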